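The source may report more compounds than this note shows. Statements on the series, on what has been measured and on what is new or still open speak of the compounds shown alone.

Measured in a functional assay on HepG2 cells (Homo sapiens) for antiproliferative activity, read by CCK-8 assay, with a stated time of 72 h, tested at 8 uM; a higher number here means a stronger effect of the compound at the concentration tested, a lower number a weaker effect:
- compound 1 `CC1CCN(c2nc(Cl)nc3c2ncn3Cc2ccc(/C=C/C(=O)Nc3ccccc3N)cc2)CC1` gives 32.2%
- compound 2 `Nc1ccccc1NC(=O)/C=C/c1ccc(Cn2cnc3c(Nc4cccc(Cl)c4)nc(Cl)nc32)cc1` gives 49.3%
- compound 3 `CC1CCN(c2nc(Cl)nc3c2ncn3Cc2ccc(C(=O)Nc3ccccc3N)cc2)CC1` gives 65.3%

Within the set, compound 3 stands highest in this assay; the step of a number 33.1 percentage points higher from compound 1 to compound 3 (beyond the scatter) is the difference ((2-aminophenyl)carbamoyl in place of 2-((2-aminophenyl)carbamoyl)ethenyl on an aromatic carbon). The change (3-chlorophenyl)amino in place of 4-methylpiperidin-1-yl on an aromatic carbon gave the step of a number 17.1 percentage points higher from compound 1 to compound 2 (beyond the scatter).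

Compound 4 `Nc1ccccc1NC(=O)c1ccc(Cn2cnc3c(Nc4cccc(Cl)c4)nc(Cl)nc32)cc1` is not yet measured. It differs from compound 3 by (3-chlorophenyl)amino in place of 4-methylpiperidin-1-yl on an aromatic carbon, the same kind of change as from compound 1 to compound 2, made on a core that differs from the core of compound 1 by (2-aminophenyl)carbamoyl in place of 2-((2-aminophenyl)carbamoyl)ethenyl on an aromatic carbon. Because the step of a number 17.1 percentage points higher from compound 1 to compound 2 (beyond the scatter) went upward from a lower starting point, an expected step of similar size, a number 12.7 percentage points higher from compound 3 to compound 4 (beyond the scatter), is taken for compound 4, with room for it to be smaller near the top of the scale. Compound 4 is thus estimated at 78% in this assay, expected between 60% and 92%.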

Compound 4, a percentage reported as inhibition, at one concentration (the size of the read-out at that concentration, not a potency): 66.7%
Compound 4: the middle estimate sits 11.3 percentage points above what was measured, and the stated range covers the measured number.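

In this assay, the change to (3-chlorophenyl)amino does not carry over at the same size once the ethenyl is gone, the step now being a number 1.4 percentage points higher from compound 3 to compound 4 (within the scatter): the same change on two cores in this assay, a number 17.1 percentage points higher (beyond the scatter) from compound 1 to compound 2 and a number 1.4 percentage points higher (within the scatter) from compound 3 to compound 4, 15.7 percentage points apart, beyond the scatter of two such steps
Loss of the ethenyl still goes in the same direction with (3-chlorophenyl)amino in place, at a number 17.4 percentage points higher from compound 2 to compound 4 (beyond the scatter), but the step is smaller than with 4-methylpiperidin-1-yl: the same change on two cores in this assay, a number 33.1 percentage points higher (beyond the scatter) from compound 1 to compound 3 and a number 17.4 percentage points higher (beyond the scatter) from compound 2 to compound 4, 15.7 percentage points apart, beyond the scatter of two such steps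
These four compounds form a single comparison at one concentration, so they show that the two changes are not additive here, but not why, nor whether this holds beyond these groups.

Still open, as far as these compounds go, is how a morpholine or a simple alkylamine would behave at the same aromatic carbon. Also open, from the compounds shown here alone, is whether a saturated two-carbon chain in place of the ethenyl would follow compound 3 or compound 1.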